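Swapping Butyl for Ethoxycarbonyl on the Shared Core

A few compounds are considered here, and "the series" means these few. Any claim that something is new, unique, unknown or untested is made for them only; others in the source may bear on it.

Three ureas have so far been measured in an ADME assay on the whole organism with Oryza sativa as the target, tested at 10 uM; on this read-out lower numbers stand for a stronger effect and higher numbers for a weaker effect at the one concentration tested. Compound 1 `CCCCc1ccc(NC(=O)N[C@H](C)c2ccccc2)cc1` gives 28%, compound 2 `CCCCc1ccc(NC(=O)N[C@@H](C)c2ccccc2)cc1` gives 60%, and compound 3 `CCCCCCc1ccc(NC(=O)N[C@H](C)c2ccccc2)cc1` gives 101%. Compound 2 thus stands second highest of the three numbers, with compound 1 nearest to it and compound 3 furthest from it. The two steps known so far are both large: a number 32 percentage points higher from compound 1 to compound 2 (beyond the scatter), which rests on (the fact that compounds 1 and 2 differ only in the configuration as drawn), and a number 73 percentage points higher from compound 1 to compound 3 (beyond the scatter).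

Compound 4 `CCOC(=O)c1ccc(NC(=O)N[C@@H](C)c2ccccc2)cc1` has not yet been measured. It differs from compound 2 in one place: ethoxycarbonyl in place of butyl on an aromatic carbon. Within the data shown here, no measured step exchanges the butyl group for anything other than a longer chain, so neither known step bears directly on this change. Among the measured compounds shown here, the step of a number 73 percentage points higher from compound 1 to compound 3 (beyond the scatter) shows only that altering the group on this aromatic carbon can move the number in this assay a long way, while the step of a number 32 percentage points higher from compound 1 to compound 2 (beyond the scatter) concerns a different part of the molecule. The direction of the coming step is therefore open, and the range around the expected number is wide. The account expects compound 4 to give about 70% in this assay, between 40% and 100%. This estimate means an expected step of a number 10 percentage points higher from compound 2 to compound 4 (within the scatter), lying within the scatter.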

Compound 4, a percentage reported as activity, at one concentration (the size of the read-out at that concentration, not a potency): 92%
Compound 4: middle estimate off by 22 percentage points, on the low side; measured number inside the range.
By their numbers in this assay, from the lowest: compound 1; then compound 2; then compounds 4 and 3 (each within the scatter of the next).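

In this assay, ethoxycarbonyl in place of butyl on the aromatic carbon para to a large group gives a number 32 percentage points higher from compound 2 to compound 4 (beyond the scatter), so this position now shows a large step for a group that is not simply a longer carbon chain but one that brings in oxygen, a double bond outside the aromatic rings and hydrogen-bond acceptors. The only earlier change at this carbon, a number 73 percentage points higher from compound 1 to compound 3 (beyond the scatter), was made with the stereocentre drawn the other way, so both replacements of butyl shown here raise the number, one under each drawn configuration, and no compound shown goes against this. Nothing reported here accounts for why the exchange of butyl for ethoxycarbonyl moves the number as it does.

The compounds shown leave open whether the step belongs to the ester as a whole or to some part of it, which a carboxylic acid, an amide or a plain propyl chain on the same aromatic carbon could begin to separate. They also leave open how ethoxycarbonyl behaves with the stereocentre drawn as in compound 1, where butyl gives the lowest number of the set.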